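The source may report more compounds than this note shows. Statements on the series, on what has been measured and on what is new or still open speak of the compounds shown alone.

Measured so far in an ADME assay on microsomes from liver (Homo sapiens) for metabolic stability, tested at 2.5 uM; a lower number here means slower removal, a higher number faster removal of the compound:

Compound 2 `O=S(=O)(c1cc(F)cc(F)c1)c1cnc2cc(F)ccc2c1-c1cccc(F)c1`: 0.06 mL/min
Compound 3 `O=S(=O)(c1ccc(F)c(F)c1)c1cnc2cc(F)ccc2c1-c1cccc(F)c1`: 0.6 mL/min
Compound 1 `COc1cccc(-c2c(S(=O)(=O)c3cc(F)cc(F)c3)cnc3cc(F)ccc23)c1`: 1.81 mL/min

Compound 2 gives the lowest number of the three. The change to compound 1, (methoxy in place of fluoro on an aromatic carbon), gave a 30-fold higher number from compound 2 to compound 1 (1.48 log units; beyond the scatter). The other change from compound 2, (3,4-difluorophenyl in place of 3,5-difluorophenyl on a sulfonyl sulfur), gave a 10-fold higher number from compound 2 to compound 3 (1.00 log units; beyond the scatter). Among the compounds with values here, compound 3 sits between the two, with compound 1 a step above it; no counted step between compound 1 and compound 3 is given here, so only their two values are compared.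

Compound 4 `COc1cccc(-c2c(S(=O)(=O)c3ccc(F)c(F)c3)cnc3cc(F)ccc23)c1` is not yet measured in this assay. It differs from compound 3 by methoxy in place of fluoro on an aromatic carbon, the same change as from compound 2 to compound 1, and the place lines of the two read the same word for word; the two cores differ as described by 3,4-difluorophenyl in place of 3,5-difluorophenyl on a sulfonyl sulfur. The step is expected to be of similar size, a 17-fold higher number from compound 3 to compound 4 (1.22 log units; beyond the scatter), resting on compound 2 to compound 1 giving a 30-fold higher number from compound 2 to compound 1 (1.48 log units; beyond the scatter) and on compound 3 starting from 0.6 mL/min. Compound 4 is therefore estimated at 10 mL/min, between 3 mL/min and 30 mL/min.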

Compound 4, intrinsic clearance in a liver preparation (reported as CLH), per the amount of preparation that the assay uses: 1.77 mL/min
Compound 4: middle estimate off by 5.6-fold (0.75 log units), on the high side; measured number outside the range, below it.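

In this assay, 3-methoxyphenyl in place of 3-fluorophenyl gives a higher number on both cores, but the size of the step does not carry over, with a 3.0-fold higher number from compound 3 to compound 4 (0.47 log units; beyond the scatter) on the core bearing the 3,4-difluorophenyl group: the same change on two cores in this assay, a 30-fold higher number (1.48 log units; beyond the scatter) from compound 2 to compound 1 and a 3.0-fold higher number (0.47 log units; beyond the scatter) from compound 3 to compound 4, 10-fold (1.01 log units) apart, beyond the scatter of two such steps. The exchange of 3,5-difluorophenyl for 3,4-difluorophenyl on the sulfonyl sulfur also depends on the core, with a 1.0-fold lower number from compound 1 to compound 4 (0.01 log units; within the scatter) where the methoxy group is present: the same change on two cores in this assay, a 10-fold higher number (1.00 log units; beyond the scatter) from compound 2 to compound 3 and a 1.0-fold lower number (0.01 log units; within the scatter) from compound 1 to compound 4, 10-fold (1.01 log units) apart, beyond the scatter of two such steps. The direction of the methoxy change therefore held across these two cores while its size did not, so a step measured on one core is a poor guide to its size on the other, and these four compounds do not show what sets that size.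

Still open, going by these compounds, is whether the same dependence on the core appears when chloro, a nitrile or a longer alkoxy chain stands in place of the methoxy group. Also open, on these data alone, is how the series responds to an amine or a carboxylic acid on either aryl group.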